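This account rests on a few compounds, and the source may have more. Where it says the series, first, only, none or still open, it means among the compounds named here.

Values in a functional assay on PC-3 cells (Homo sapiens) for inhibition, read by MTT assay, with a stated time of 48 h; a lower number here means a stronger inhibitor, a higher number a weaker inhibitor:

compound 1 `COc1cc(N(Cc2nc3ccccc3[nH]2)S(=O)(=O)c2ccc(C)cc2)cc(OC)c1OC`: 3340 nM
compound 2 `COc1cc(N(Cc2nc3ccccc3[nH]2)S(=O)(=O)c2ccc(C(C)(C)C)cc2)cc(OC)c1OC`: 29800 nM
compound 3 `COc1cc(N(Cc2nc3ccccc3[nH]2)C(=O)c2ccc(C)cc2)cc(OC)c1OC`: 42000 nM

Compound 1 carries the lowest number of the three. Compound 2 differs from it by tert-butyl in place of methyl on an aromatic carbon, and that change gave an 8.9-fold higher number from compound 1 to compound 2 (0.95 log units; beyond the scatter). Compound 3 differs from compound 1 in the core: (4-methylphenyl)carbonyl in place of (4-methylphenyl)sulfonyl on a nitrogen on an aromatic ring, and this gave a 13-fold higher number from compound 1 to compound 3 (1.10 log units; beyond the scatter). Compound 2 and compound 3 lie within the scatter of each other, so no order between them is claimed.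

Compound 4 `COc1cc(N(Cc2nc3ccccc3[nH]2)C(=O)c2ccc(C(C)(C)C)cc2)cc(OC)c1OC` is not yet measured. It differs from compound 3 by tert-butyl in place of methyl on an aromatic carbon, the same change that separates compound 2 from compound 1, at a place described in the same words. Among the measured compounds shown here, only one instance of this change has been measured, so the expectation rests on that single step. Compound 4 is expected to sit higher than compound 3, with a 6.0-fold higher number from compound 3 to compound 4 (0.77 log units; beyond the scatter) estimated, because an 8.9-fold higher number from compound 1 to compound 2 (0.95 log units; beyond the scatter) was seen on the other core. Since compound 3 already stands at 42000 nM, compound 4 may run past the range the assay reports. Compound 4 is estimated at 250000 nM, within 50000 nM to 1200000 nM.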

Compound 4, half-maximal inhibitory concentration: 46000 nM
Compound 4: middle estimate off by 5.4-fold (0.74 log units), on the high side; the measured number lies below the stated range.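

In this assay, tert-butyl in place of methyl on an aromatic carbon does not carry from one core to the other with the same size: the same change on two cores in this assay, an 8.9-fold higher number (0.95 log units; beyond the scatter) from compound 1 to compound 2 and a 1.1-fold higher number (0.04 log units; within the scatter) from compound 3 to compound 4, 8.1-fold (0.91 log units) apart, beyond the scatter of two such steps

On the carbonyl core the step reads a 1.1-fold higher number from compound 3 to compound 4 (0.04 log units; within the scatter), so the size seen on the sulfonyl core gives no usable forecast for this change on the carbonyl core. These notes do not show why the two cores part, and with one pair per core they cannot say whether the difference would hold for other substituents or is specific to this pair.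

The compounds shown leave open how other groups at that aromatic carbon would behave on either core, such as a chlorine, a methoxy, an amine or a carboxylic acid. Also open, from the compounds shown here alone, is whether a link other than sulfonyl or carbonyl on the nitrogen, such as a plain methylene, would respond to the change like either core.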